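The compounds below may be only part of what the source reports. "The series", "measured", "known", "first", "only" and "open" are said of these compounds alone.

Compounds measured in a functional assay on HEK-EM293 cells for agonist activity at Thyrotropin receptor (Homo sapiens), read by ELISA and cAMP accumulation, with a stated time of 1 h; on this read-out lower numbers stand for an effect already at smaller amounts and higher numbers for an effect only at larger amounts of compound:
Compound 1 `COc1ccc(C2Nc3cccc(O)c3C(=O)N2Cc2ccccc2)cc1COc1ccc(NC(C)=O)cc1` gives 90 nM.
Compound 2 `COc1ccc(C2Nc3cccc(OC)c3C(=O)N2Cc2ccccc2)cc1COc1ccc(NC(C)=O)cc1` gives 4480 nM.
Compound 3 `COc1ccc(C2Nc3cccc(F)c3C(=O)N2Cc2ccccc2)cc1COc1ccc(NC(C)=O)cc1` gives 280 nM.

Compound 1 stands lowest of the three numbers. The step of a 50-fold higher number from compound 1 to compound 2 (1.70 log units; beyond the scatter) is large, the step of a 3.1-fold higher number from compound 1 to compound 3 (0.49 log units; beyond the scatter) is modest, and the step of a 16-fold lower number from compound 2 to compound 3 (1.20 log units; beyond the scatter) is again large. All three steps concern a single position on the shared core, where hydroxy, methoxy and fluoro were compared. Compound 4 `COc1ccc(C2Nc3cccc(O)c3C(=O)N2Cc2ccccc2)cc1CSc1ccc(NC(C)=O)cc1` differs from compound 1 at a different place: (4-acetamidophenyl)sulfanyl in place of 4-acetamidophenoxy on a saturated chain carbon bound to an aromatic carbon. Among the measured compounds shown here, none of the measured steps touches this part of the molecule, so they offer no direct guide to the size or direction of the change. The hydroxy group on the core that compound 1 carries, and that goes with the lowest number, is kept in compound 4. Compound 4 is therefore expected to stay near compound 1, with the step of a 1.7-fold higher number from compound 1 to compound 4 (0.22 log units; within the scatter) expected to fall within or close to the scatter. The estimate for compound 4 is 150 nM, within a range from 45 nM to 500 nM.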

Compound 4, half-maximal effective concentration: 18 nM
For compound 4 the middle estimate is 8.3-fold (0.92 log units) above the measured one, outside the stated range (below it).
By their numbers in this assay, from the lowest: compound 4; then compound 1; then compound 3; then compound 2.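

In this assay, among the compounds shown here, the change from 4-acetamidophenoxy to (4-acetamidophenyl)sulfanyl gives a 5.0-fold lower number from compound 1 to compound 4 (0.70 log units; beyond the scatter) and so shows that the number also responds beyond the scatter to a change on a saturated chain carbon bound to an aromatic carbon, a place the earlier compounds left untouched. The two groups match in heavy atoms, hydrogen-bond donors and hydrogen-bond acceptors, and their composition differs only by sulfur in place of one oxygen, so this single exchange of atoms is enough for a step of this size. Nothing measured here accounts for the step.

Going by these compounds, it remains open whether methoxy or fluoro on the core would shift the number as far with the (4-acetamidophenyl)sulfanyl group in place as with 4-acetamidophenoxy. Also open, on these data alone, is whether a sulfinyl or sulfonyl group, or a methylene group, in place of the sulfur would lower the number further.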